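The source may report more compounds than this note shows. Statements on the series, on what has been measured and on what is new or still open speak of the compounds shown alone.

Compound 1 `O=C(CSc1nc2ccccc2[nH]1)c1ccc(O)cc1`: "not active" (no number reported)
Compound 2 `COc1ccc(C(=O)CSc2nc3ccccc3[nH]2)cc1OC`: 52.6%
Compound 3 `O=C(CSc1nc2ccccc2[nH]1)c1ccc(F)cc1`: "not active" (no number reported)

In a functional assay on HT-29 cells (Homo sapiens) for inhibition, read by flow cytometry, tested at 10 uM (a higher number here means more inhibition at the concentration tested (going by the name of the read-out), a lower number less inhibition), compound 1 gives "not active" (no number reported), so no number stands for it. Compound 3 likewise gives "not active" (no number reported) in this assay. Only compound 2 gives a number in this assay, namely 52.6%. Compound 4 `COc1ccc(C(=O)CSc2nc3ccccc3[nH]2)cc1` has not yet been measured. It differs from compound 1 by methyl in place of hydrogen on an oxygen on an aromatic ring. Among the compounds with values here, no measured pair of compounds shows the size of this change. Compound 2, which bears two methoxy groups, does give a number where compound 1 does not, so a step upward beyond the scatter is expected for compound 4, though a report of no activity remains possible. For compound 4 the inhibition is expected at 30%, within 0% to 55%.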

Compound 4, a percentage reported as inhibition, at one concentration (the size of the read-out at that concentration, not a potency): 52.6%
Beside the measured number, compound 4's estimate is 22.6 percentage points below it; the measured number falls inside the stated range.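

In this assay there is no change at the digits printed from compound 2 to compound 4 (within the scatter), so a single methoxy group on the aromatic ring is enough for the inhibition seen, and a second one adds nothing measurable. The methyl on that oxygen now stands out: with hydrogen in its place, compound 1 gives "not active" (no number reported), whereas compound 4 gives a number. Nothing shown here explains this difference.

On these data alone, whether a longer chain on that oxygen, as in ethoxy, would keep the inhibition remains open. So does the outcome with an amine in place of the methoxy group.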